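A Fluoro-to-Hydrogen Step in a Small Cytotoxicity Set

The source may hold more compounds than are shown below. What is called first, only, known or untested is meant among the compounds shown, and "the series" means these compounds.

Compound 1, `CC(C)COC(=O)Nc1ccc([Se][Se]c2ccc(NC(=O)OCC(C)C)cc2)cc1`: 24200 nM
Compound 2, `N#C[Se]c1ccc(NC(=O)Oc2ccc(F)cc2)cc1`: 11800 nM
Compound 3, `O=C(Nc1ccc([Se][Se]c2ccc(NC(=O)OCc3ccc([N+](=O)[O-])cc3)cc2)cc1)OCc1ccc([N+](=O)[O-])cc1`: 6400 nM

These three values come from a functional assay on PC-3 cells (Homo sapiens) for cytotoxicity, read by MTT assay, with a stated time of 72 h; on this read-out lower numbers stand for stronger inhibition of growth and higher numbers for weaker inhibition of growth. Among them, compound 2 holds the second highest number; its nearest neighbour is compound 3, whose number lies within the scatter of it, and its furthest is compound 1, whose number lies beyond the scatter on the weaker side. No pair of these measured compounds differs in just one place, so no single-change step is shown.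

Compound 4, `N#C[Se]c1ccc(NC(=O)Oc2ccccc2)cc1`, differs from compound 2 by hydrogen in place of fluoro on an aromatic carbon. Among the compounds with values here, with no comparable step among the measured compounds, the expected change in this assay from compound 2 to compound 4 is none beyond the scatter, and the step of a 1.2-fold higher number from compound 2 to compound 4 (0.07 log units; within the scatter) is an estimate. Compound 4 is therefore expected to give 14000 nM, within a range from 6000 nM to 35000 nM.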

Compound 4, concentration for 50% growth inhibition: 9100 nM
Compound 4: middle estimate off by 1.5-fold (0.19 log units), on the high side; the range from low to high includes it.
By their numbers in this assay, from the lowest: compounds 3, 4 and 2 (each within the scatter of the next); then compound 1.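

Hydrogen in place of fluoro on an aromatic carbon, para to a large group, gives the first single-change comparison in this set: in this assay the change is a 1.3-fold lower number from compound 2 to compound 4 (0.11 log units; within the scatter) and so does not separate the two compounds. At this position, fluoro is therefore not required for the growth inhibition seen with compound 2. No measurement shown here bears on this result.

From the compounds shown here alone, whether an amine or a carboxylic acid on this carbon would shift the number beyond the scatter remains open. So does whether a chloro or methoxy group would.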